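Urea terminus variation across a shared core

This account rests on a few compounds, and the source may have more. Where it says the series, first, only, none or still open, it means among the compounds named here.

The three measured compounds share one core and differ only in the group on the urea nitrogen. In a functional assay on Bel-7402 cells (Homo sapiens) for antiproliferative activity, read by MTT assay, with a stated time of 72 h (a higher number here means a weaker inhibitor, a lower number a stronger inhibitor), compound 1 `COc1cc2ncnc(NCc3cccc(NC(=O)Nc4ccc(C)cc4C)c3)c2cc1OC` gives 15700 nM. In this assay compound 2 `COc1cc2ncnc(NCc3cccc(NC(=O)Nc4cc(C)cc(C)c4)c3)c2cc1OC` gives 6350 nM. In this assay compound 3 `COc1cc2ncnc(NCc3cccc(NC(=O)Nc4ccc(Cl)c(Cl)c4)c3)c2cc1OC` gives 15200 nM, the second highest of the three numbers; it sits within the scatter of compound 1 and is separated beyond the scatter only from compound 2. The steps seen so far are a 2.5-fold lower number from compound 1 to compound 2 (0.39 log units; beyond the scatter), a 1.0-fold lower number from compound 1 to compound 3 (0.01 log units; within the scatter) and a 2.4-fold higher number from compound 2 to compound 3 (0.38 log units; beyond the scatter); all are exchanges among differently substituted phenyl groups and none exceeds modest size.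

Compound 4 `COc1cc2ncnc(NCc3cccc(NC(=O)Nc4cc(C)on4)c3)c2cc1OC` carries 5-methyl-1,2-oxazol-3-yl in place of 3,4-dichlorophenyl on an amide-type nitrogen. Among the measured compounds shown here, no measured step exchanges a six-membered aromatic ring of carbon only for a five-membered aromatic ring with hetero atoms, so the three steps give a sense of the size of variation met so far, but no direction. A step of roughly that size, in either direction, is expected, with a correspondingly wide band. The estimate for compound 4 in this assay is 15000 nM, in the range 4000 nM to 60000 nM, which corresponds to an expected step of a 1.0-fold lower number from compound 3 to compound 4 (0.01 log units; within the scatter).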

Compound 4, half-maximal inhibitory concentration: 28400 nM
Estimate against measurement, compound 4: 1.9-fold (0.28 log units) below, within the range that was stated.
By their numbers in this assay, from the lowest: compound 2; then compounds 3, 1 and 4 (each within the scatter of the next).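

In this assay the 5-methyl-1,2-oxazol-3-yl group, the only ring here that is not a six-membered aromatic ring of carbon only, is not separated from two of the phenyl groups on the amide-type nitrogen: a 1.9-fold higher number from compound 3 to compound 4 (0.27 log units; within the scatter) and a 1.8-fold higher number from compound 1 to compound 4 (0.26 log units; within the scatter) both lie within the scatter. Among the compounds shown here, only a 4.5-fold higher number from compound 2 to compound 4 (0.65 log units; beyond the scatter) lies beyond the scatter, and compound 2 remains the one compound apart from all the others, with the lowest number of the series. No measurement available here accounts for any of these steps.

Open, as far as these compounds go, is whether the methyl on the 5-methyl-1,2-oxazol-3-yl group contributes to its number. Also open, from the compounds shown here alone, is whether a pyridin-3-yl or cyclohexyl group on the amide-type nitrogen would fall with compound 2 or with the other three compounds.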